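The source may hold more compounds than are shown below. What is called first, only, known or untested is meant among the compounds shown, and "the series" means these compounds.

Three compounds have been measured in an ADME assay on the whole organism with Oryza sativa as the target, tested at 0.1 uM; a higher number here means a weaker effect of the compound at the concentration tested, a lower number a stronger effect:

Compound 1 `C[C@H](NC(=O)Nc1ccccc1C(C)(C)C)c1ccccc1`: 101%
Compound 2 `C[C@H](NC(=O)Nc1ccccc1C(F)(F)F)c1ccccc1`: 97%
Compound 3 `CC(=O)c1ccccc1NC(=O)N[C@@H](C)c1ccccc1`: 100%

Compound 1 has the highest of the three numbers, but by little: compound 3 follows at a number 1 percentage points lower from compound 1 to compound 3 (within the scatter), and compound 2 at a number 4 percentage points lower from compound 1 to compound 2 (within the scatter). Between compound 2 and compound 3 the step is a number 3 percentage points higher from compound 2 to compound 3 (within the scatter). All three numbers lie close to the top of the scale.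

Compound 4 `C[C@H](NC(=O)Nc1cc(C(C)(C)C)ccc1C(C)(C)C)c1ccccc1` differs from compound 1 by tert-butyl in place of hydrogen on an aromatic carbon. Among the compounds with values here, no measured step adds a group at such a place; the three measured steps exchange one group for another and every one of them stays within the scatter. So nothing among the measured compounds points to a step beyond the scatter in this assay, in either direction. Compound 4 is therefore expected to give 99%, with a range from 88% to 106%. The estimated step of a number 2 percentage points lower from compound 1 to compound 4 (within the scatter) is expected to remain within the scatter.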

Compound 4, a percentage reported as activity, at one concentration (the size of the read-out at that concentration, not a potency): 98%
For compound 4 the middle estimate is 1 percentage points above the measured one; low and high end bracket the measured number.
By their numbers in this assay, from the lowest: compounds 2, 4, 3 and 1 (each within the scatter of the next).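

Within the data shown here, compound 4 is the first to add a group rather than exchange one, and it places tert-butyl on an aromatic carbon that the earlier compounds leave carrying hydrogen, meta to a large group and para to a tert-butyl group. In this assay this addition gives a number 3 percentage points lower from compound 1 to compound 4 (within the scatter), so even a group of this size at this place produces no step beyond the scatter. Nothing available bears on why the number stays where it does.

The compounds shown leave open whether an amine or a carboxylic acid at this same place would give a step beyond the scatter. They also leave open whether any change elsewhere on the core of compound 1 would move the number away from the top of the scale.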